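The compounds below may be only part of what the source reports. "The series", "measured", "known", "first", "only" and "open" are said of these compounds alone.

Going by the values given here, in an ADME assay on microsomes from liver (Rattus norvegicus) for metabolic stability, read by LC-MS, in the presence of a further agent that is not named here (on this read-out higher numbers stand for fast clearance and lower numbers for slow clearance), compound 2 `Cc1ncc(C)n2nc(-c3ccn4cc(-c5ccccc5)nc4n3)nc12` gives 5.6 mL.min-1.g-1, the lower of the two numbers measured so far, while compound 1 `Cc1ncc(C)n2nc(-c3ccn4cc(-c5ccc(Br)cc5)nc4n3)nc12` gives 15 mL.min-1.g-1. Compound 3 `Cc1ncc(C)n2nc(-c3ccn4cc(-c5ccccc5Br)nc4n3)nc12` has not yet been measured. It differs from compound 2 by a single change, bromo in place of hydrogen on an aromatic carbon, which turns phenyl into 2-bromophenyl: bromo in place of hydrogen on an aromatic carbon. Among the compounds with values here, only one measured step bears on this change: a 2.7-fold lower number from compound 1 to compound 2 (0.43 log units; beyond the scatter), where hydrogen replaces bromo on an aromatic carbon. Read in reverse, that step points to a higher number when bromo is present. However, compound 1 carries its bromo at a different place on that ring from compound 3, and no measurement covers bromo at the new place, so the step transfers only loosely. In this assay a rise is therefore expected, smaller than the measured step and possibly not beyond the scatter. The expected step is a 1.6-fold higher number from compound 2 to compound 3 (0.21 log units; within the scatter). For compound 3 the estimated value is 9 mL.min-1.g-1, with an expected range from 4 mL.min-1.g-1 to 20 mL.min-1.g-1.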

Compound 3, intrinsic clearance in microsomes: 1.8 mL.min-1.g-1
Beside the measured number, compound 3's estimate is 5.0-fold (0.70 log units) above it; the whole stated range lies above it.
By their numbers in this assay, from the lowest: compound 3; then compound 2; then compound 1.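

In this assay bromo in place of hydrogen on an aromatic carbon gives no single direction: as 2-bromophenyl, ortho to a large group, it brings a 3.1-fold lower number from compound 2 to compound 3 (0.49 log units; beyond the scatter) and so runs against the earlier step, a 2.7-fold lower number from compound 1 to compound 2 (0.43 log units; beyond the scatter), in which losing the bromo of compound 1 lowered the number. With the bromo kept and only its place changed, the data show an 8.3-fold lower number from compound 1 to compound 3 (0.92 log units; beyond the scatter) and this is the largest step among the three compounds, so the direction of the bromo step in this series goes with where the bromo sits and not merely with its presence. Nothing available here accounts for this difference between the two places.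

The compounds shown leave open whether fluoro, chloro, methyl or methoxy on the same aromatic carbon, ortho to a large group, would also lower the number as bromo does in compound 3. They also leave open whether an amine or a carboxylic acid at that carbon would follow compound 3 or compound 1 on this read-out.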